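Aryl variation on the urea nitrogen of the shared core

The compounds below may be only part of what the source reports. "The series", "measured", "known", "first", "only" and "open" are said of these compounds alone.

Three compounds of this series have numbers in an assay on isolated protein for antagonist activity at transient receptor potential cation channel subfamily V member 1 (Homo sapiens); a lower number here means a stronger inhibitor, a higher number a weaker inhibitor. Compound 3 `O=C(Nc1ccc(Cl)cc1)N1CCN(c2ccnc(Cl)n2)CC1` gives 1250 nM, the second highest of the three. Compound 1 `O=C(Nc1cccc(Br)c1)N1CCN(c2ccnc(Cl)n2)CC1` gives 1450 nM, and the step of a 1.2-fold lower number from compound 1 to compound 3 (0.06 log units; within the scatter) is within the scatter, so the two halophenyl ureas cannot be told apart. Going by the values given here, compound 2 `O=C(Nc1ccccc1C(F)(F)F)N1CCN(c2ccnc(Cl)n2)CC1` gives 136 nM, a clearly lower number than compound 3, and it is the only member whose aryl carries its substituent as a 2-substituted phenyl.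

Compound 4 `COc1ccccc1NC(=O)N1CCN(c2ccnc(Cl)n2)CC1` is not yet measured. The change from compound 3 is 2-methoxyphenyl in place of 4-chlorophenyl on an amide-type nitrogen. No measured step covers this exact swap; the only step shown, from compound 1 to compound 3, says a halogen moved around the ring does nothing beyond the scatter. Compound 2 shows that a 2-substituted phenyl can sit far lower than compound 3, although its substituent differs from methoxy. The expectation is therefore a lower number for compound 4, by a step of a 2.8-fold lower number from compound 3 to compound 4 (0.44 log units; beyond the scatter), placed between compound 2 and compound 3 but with wide uncertainty.

Compound 4 is estimated at 450 nM, in the range 120 nM to 1600 nM.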

Compound 4, half-maximal inhibitory concentration: 9420 nM
Compound 4: middle estimate off by 21-fold (1.32 log units), on the low side; measured number outside the range, above it.
By their numbers in this assay, from the lowest: compound 2; then compounds 3 and 1 (each within the scatter of the next); then compound 4.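

In this assay, the change of methoxy in place of trifluoromethyl on an aromatic carbon gives a 69-fold higher number from compound 2 to compound 4 (1.84 log units; beyond the scatter) and is the largest step in the series, so the low number of compound 2 does not carry over to the 2-methoxyphenyl urea. The 2-methoxyphenyl group also falls apart from both halophenyl ureas, with a 7.5-fold higher number from compound 3 to compound 4 (0.88 log units; beyond the scatter) and a 6.5-fold higher number from compound 1 to compound 4 (0.81 log units; beyond the scatter), so aryl choice on this amide-type nitrogen moves the number in both directions from the halophenyl pair: compound 2 lower, compound 4 higher. Nothing on hand accounts for these differences.

Open, as far as these compounds go, is whether the low number is specific to trifluoromethyl or extends to other groups on the phenyl, such as a nitrile, a methyl or an amine. Also open, from the compounds shown here alone, is whether trifluoromethyl elsewhere on the phenyl would keep that number.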